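This account rests on a few compounds, and the source may have more. Where it says the series, first, only, none or still open, it means among the compounds named here.

Compound 1 `N#Cc1ccc2nc(-c3cncnc3C(F)F)n(C3CC3)c2c1` and compound 2 `N#Cc1ccc2nc(-c3cncnc3C(F)(F)F)n(C3CC3)c2c1` share one core. In an ADME assay on microsomes from liver (Macaca fascicularis) for metabolic stability, read by LC-MS, with a stated time of 65 min, tested at 1 uM (on this read-out lower numbers stand for a less stable compound and higher numbers for a more stable compound), compound 1 gives 84% and compound 2 gives 62%. The change between them, (fluoro in place of hydrogen on a saturated chain carbon bound to an aromatic carbon and two fluorine atoms), made the step of a number 22 percentage points lower from compound 1 to compound 2 (beyond the scatter). Compound 3 `N#Cc1ccc2nc(-c3cncnc3C(F)F)n(C3CC3)c2n1` rests on a different core; the difference between the two cores is not broken down here. In this assay compound 3 gives 101%, the highest of the three numbers. Compound 4 `N#Cc1ccc2nc(-c3cncnc3C(F)(F)F)n(C3CC3)c2n1` is not yet measured; it differs from compound 3 by the same change, (fluoro in place of hydrogen on a saturated chain carbon bound to an aromatic carbon and two fluorine atoms). Because the first occurrence gave a number 22 percentage points lower from compound 1 to compound 2 (beyond the scatter), a similar downward step is expected here, so that the estimated step from compound 3 to compound 4 in this assay is a number 22 percentage points lower from compound 3 to compound 4 (beyond the scatter). For compound 4 the expected value in this assay is 79%, likely between 64% and 94%.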

Compound 4, percent of the compound remaining: 87%
Compound 4: middle estimate off by 8 percentage points, on the low side; the measured number falls inside the stated range.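

In this assay, the change from difluoromethyl to trifluoromethyl again lowers the number, a number 14 percentage points lower from compound 3 to compound 4 (beyond the scatter), and the direction seen on the core of compound 1 therefore holds on the core of compound 3. The size of the step also carries over, as far as the scatter of such measurements can tell: the same change on two cores in this assay, a number 22 percentage points lower (beyond the scatter) from compound 1 to compound 2 and a number 14 percentage points lower (beyond the scatter) from compound 3 to compound 4, 8 percentage points apart, within the scatter of two such steps. For the compounds shown here, these are only two pairs of compounds in a single assay, which does not show that the step would hold on any further core or in another read-out, and they do not explain why the step occurs.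

The compounds shown carry only difluoromethyl or trifluoromethyl at this place. From the compounds shown here alone, what a plain methyl, an amine or a longer chain there would do to the percent remaining stays open.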